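The source may report more compounds than this note shows. Statements on the series, on what has been measured and on what is new or still open speak of the compounds shown alone.

Measured in a functional assay on SW480 cells (Homo sapiens) for antiproliferative activity, read by sulforhodamine B assay, with a stated time of 48 h (on this read-out higher numbers stand for weaker inhibition and lower numbers for stronger inhibition), are:
compound 1 `COc1ccc(/C=C/C(=O)c2ccccc2-c2ccc(F)cc2)cc1` with 61 nM
compound 2 `COc1ccc(/C=C/C(=O)c2ccccc2-c2ccc(F)cc2)cc1O` with 57 nM
compound 3 `COc1ccc(/C=C/C(=O)c2ccccc2-c2ccc(F)cc2)cc1B(O)O` with 41 nM

Compound 1 lies within the usual scatter of the other two values, so the numbers do not separate it from them. Compound 4 `COc1ccc(/C=C/C(=O)c2ccccc2-c2cccnc2)cc1` has pyridin-3-yl in place of 4-fluorophenyl (pyridin-3-yl in place of 4-fluorophenyl on an aromatic carbon). The two measured steps that start from this compound (a 1.1-fold lower number from compound 1 to compound 2 (0.03 log units; within the scatter) and a 1.5-fold lower number from compound 1 to compound 3 (0.17 log units; within the scatter)) both stayed within the scatter. Neither touched the 4-fluorophenyl group, so they say little about this swap, and no measurement covers that place. Exchanging a whole ring group is a larger edit than either step, so a modest move towards weaker inhibition is expected. The expected step (a 2.0-fold higher number from compound 1 to compound 4 (0.29 log units; within the scatter)) carries real uncertainty. For compound 4 the estimated value is 120 nM (expected range 30 nM to 500 nM).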

Compound 4, half-maximal inhibitory concentration: 200 nM
Compound 4: the middle estimate sits 1.7-fold (0.22 log units) below what was measured; low and high end bracket the measured number.
By their numbers in this assay, from the lowest: compounds 3, 2 and 1 (each within the scatter of the next); then compound 4.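

In this assay the swap of 4-fluorophenyl for pyridin-3-yl gives a step beyond the scatter (a 3.3-fold higher number from compound 1 to compound 4 (0.52 log units; beyond the scatter)), whereas the two earlier changes elsewhere on the molecule stayed within it. This place is therefore the first in the series where a single change separates two compounds, and the change goes towards weaker inhibition. No measurement available here explains this step.

From the compounds shown here alone, the swap removes the fluorine and adds the ring nitrogen together, so their shares stay unknown. A plain phenyl group here would help tell them apart.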